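A few compounds are considered here, and "the series" means these few. Any claim that something is new, unique, unknown or untested is made for them only; others in the source may bear on it.

Compound 2 `COc1ccc(/C(=N\OC(C)=O)c2ccc3c(ccn3C)c2)c(OC)c1OC` was tested in a functional assay on HT-29 cells (Homo sapiens) for cytotoxicity, read by XTT assay, with a stated time of 72 h (on this read-out lower numbers stand for stronger inhibition and higher numbers for weaker inhibition), where compound 2 gives 1500 nM. Of the two plain numbers shown, compound 2 has the lowest, but compound 1 `CCn1ccc2cc(/C(=N/O)c3ccc(OC)c(OC)c3OC)ccc21`, which gives 2000 nM in this assay, sits within the usual scatter of compound 2, so the two cannot be ranked. Compound 3 `CCn1ccc2cc(/C(=N/N)c3ccc(OC)c(OC)c3OC)ccc21` is reported in this assay only as a limit, > 10000 nM, not as a measured number. That entry is the limit of > 10000 nM in this assay, at which 1 of the 3 values shown sits.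

Compound 4 `COc1ccc(/C(=N\NC(C)=O)c2ccc3c(ccn3C)c2)c(OC)c1OC` has not yet been measured. It differs from compound 2 in one place: acetamido in place of acetoxy on a double-bonded nitrogen. Among the measured compounds shown here, the one measured step that resembles this change is an at least 5.0-fold higher number from compound 1 to compound 3 (0.69 log units; beyond the scatter), where a hydroxy on the same kind of double-bonded nitrogen became an amino, the same swap of an oxygen attachment for a nitrogen attachment that distinguishes compound 4 from compound 2. On that basis a higher number, meaning weaker inhibition, is expected for compound 4 in this assay, with a size similar to the step from compound 1 to compound 3. Compound 4 is therefore estimated at about 7500 nM, most likely between 2500 nM and 30000 nM. That estimate means a 5.0-fold higher number from compound 2 to compound 4 (0.70 log units; beyond the scatter) is expected, and a further limit rather than a number is quite possible.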

Compound 4, half-maximal inhibitory concentration: 2000 nM
Beside the measured number, compound 4's estimate is 3.8-fold (0.57 log units) above it, and the stated range ends above it.
By their numbers in this assay, from the lowest: compounds 2, 1 and 4 (each within the scatter of the next). At a limit, above all of these: compound 3.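

In this assay, acetamido in place of acetoxy on the double-bonded nitrogen gives a 1.3-fold higher number from compound 2 to compound 4 (0.12 log units; within the scatter), so in this pair, an attachment through nitrogen in place of one through oxygen leaves the number unchanged within the scatter, even though acetamido carries a hydrogen-bond donor that acetoxy lacks. The earlier step, an at least 5.0-fold higher number from compound 1 to compound 3 (0.69 log units; beyond the scatter), therefore cannot be read as a general penalty for nitrogen at this place, as compound 4 goes against that reading. Compound 3 remains the only limit among the compounds shown, not a measured number: the limit of > 10000 nM in this assay, at which 1 of the 4 values shown sits.

Compound 3 and compound 4 differ in more than one place, so these compounds cannot show whether the carbonyl of the acetamido group is what separates them. From the compounds shown here alone, what a methoxy, a methylamino or a benzamido group on the double-bonded nitrogen would give in this assay also stays open, as does whether the acetamido result holds with an ethyl chain in place of the methyl on the shared core.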